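From a Methyl to a Methoxy on the Aryl Ether

This account rests on a few compounds, and the source may have more. Where it says the series, first, only, none or still open, it means among the compounds named here.

Compound 2 `Cc1ccc(OCc2nnc(C(=O)Nc3ccc(CCC(=O)O)cc3)s2)cc1` has the highest of the two numbers measured in a functional assay on CHO cells for agonist activity at Free fatty acid receptor 1 (Homo sapiens), read by FLIPR and calcium flux, tested at 1 uM (on this read-out higher numbers stand for an effect only at larger amounts of compound and lower numbers for an effect already at smaller amounts), where compound 2 gives 2170 nM. Its nearest neighbour is compound 1 `O=C(O)CCc1ccc(NC(=O)c2nnc(COc3ccc4c(c3)CCC4)s2)cc1`, which in this assay gives 1380 nM; the step of a 1.6-fold higher number from compound 1 to compound 2 (0.20 log units; within the scatter) puts 4-methylphenyl in place of 2,3-dihydro-1H-inden-5-yl on an oxygen on a saturated carbon. Compound 3 `COc1ccc(OCc2nnc(C(=O)Nc3ccc(CCC(=O)O)cc3)s2)cc1` differs from compound 2 by methoxy in place of methyl on an aromatic carbon, para to a large group. For the measured compounds named here, no measured step exchanges a methyl for a methoxy, so there is no direct guide. Going by the values given here, the only step that alters this aryl part, a 1.6-fold higher number from compound 1 to compound 2 (0.20 log units; within the scatter), stays within the scatter, which gives no sign of a large effect from changes there. A step of similarly small size is therefore expected for compound 3, namely a 1.1-fold lower number from compound 2 to compound 3 (0.04 log units; within the scatter) in this assay, with no clear direction. Compound 3 is estimated at 2000 nM, with a range from 700 nM to 6000 nM.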

Compound 3, half-maximal effective concentration: 2430 nM
For compound 3 the middle estimate is 1.2-fold (0.08 log units) below the measured one; the range from low to high includes it.
By their numbers in this assay, from the lowest: compounds 1, 2 and 3 (each within the scatter of the next).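

In this assay, the direct exchange of methyl for methoxy on the aromatic carbon, para to a large group, gives a 1.1-fold higher number from compound 2 to compound 3 (0.05 log units; within the scatter). For the compounds shown here, this is the first direct reading of that exchange, and it shows that one more heavy atom, an oxygen that adds one hydrogen-bond acceptor, leaves the number within the scatter. The change from the two-ring group of compound 1 to 4-methoxyphenyl gives a 1.8-fold higher number from compound 1 to compound 3 (0.25 log units; within the scatter), so all three aryl groups on this ether oxygen lie within the scatter of one another, and no separate measurement bears on this result.

Still open, going by these compounds, is whether an amine or a carboxylic acid at this same place would move the number beyond the scatter. On these data alone, a longer chain, such as butoxy in place of methoxy, remains equally open.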